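From a Thiazole to a Phenyl on a Dichloroacetamide

This account rests on a few compounds, and the source may have more. Where it says the series, first, only, none or still open, it means among the compounds named here.

Compound 1 `O=C(Nc1cccc(-c2nccs2)c1)C(Cl)Cl` carries a dichloroacetamide on a benzene core that also bears a 1,3-thiazol-2-yl group. In a functional assay on NCI-H460 cells (Homo sapiens) for cytotoxicity, read by MTT assay, with a stated time of 68 h (a higher number here means a weaker inhibitor, a lower number a stronger inhibitor), compound 1 gives > 50000 nM, which is a limit of the assay and not a measured number. This places compound 1 at the limit of > 50000 nM in this assay, at which 1 of the 3 values shown sits. Two related compounds carrying two aromatic groups rather than one do give numbers: compound 2 `COc1cc(F)cc(-c2cc(NC(=O)C(Cl)Cl)cc(-c3cc(F)cc(OC)c3)c2)c1` gives 2900 nM in this assay, and compound 3 `CCOc1ccc(-c2cc(NC(=O)C(Cl)Cl)cc(-c3ccc(OCC)cc3)c2)cc1` gives 6080 nM in this assay. Neither differs from compound 1 in one place only, so they show merely that compounds of this family can reach measurable values.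

Compound 4 `O=C(Nc1cccc(-c2ccccc2)c1)C(Cl)Cl` follows from compound 1 by phenyl in place of 1,3-thiazol-2-yl on an aromatic carbon. Going by the values given here, no step between measured compounds resembles this change, so its size can only be guessed. Because compound 1 sits at the limit of > 50000 nM in this assay, at which 1 of the 3 values shown sits, a step toward weaker inhibition could not be seen at all, and only a step toward stronger inhibition would appear as a number. Compound 4 keeps the same dichloroacetamide on the same core, so the step of an at least 1.2-fold lower number from compound 1 to compound 4 (0.09 log units; that floor lies within the scatter) is expected to be small, if any, and within the usual scatter. For compound 4 the expected value in this assay is 40000 nM, within a range from 10000 nM to 100000 nM, with a fair chance that again only a limit is reported.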

Compound 4, half-maximal inhibitory concentration: 20200 nM
Compound 4: the middle estimate sits 2.0-fold (0.30 log units) above what was measured; measured number inside the range.
By their numbers in this assay, from the lowest: compound 2; then compound 3; then compound 4. At a limit, above all of these: compound 1.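

In this assay, going by these compounds alone, phenyl in place of 1,3-thiazol-2-yl on an aromatic carbon gives an at least 2.4-fold lower number from compound 1 to compound 4 (0.39 log units; beyond the scatter), and this is the first single change in the family that can be read at all. The earlier compounds showed only that measurable values exist among these dichloroacetamides, whereas this pair shows that the ring at this one position matters on its own, with the dichloroacetamide and the shared core left unchanged. The printed step is only a floor and the real gap could be larger, because the value of compound 1 is a limit and not a number: the limit of > 50000 nM in this assay, at which 1 of the 4 values shown sits.

Nothing shown tells whether the gain belongs to phenyl in particular or would also come with another ring or group at this position, such as a pyridine ring, an amine or a carboxylic acid. No compound shown differs from compound 4 in one place only, so the effect of a single methoxy or ethoxy group on its phenyl ring, or of a second phenyl ring on the core, remains open.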